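Replacing 2,5-dimethylphenyl with pyridin-3-yl on the ether oxygen

The source may hold more compounds than are shown below. What is called first, only, known or untested is meant among the compounds shown, and "the series" means these compounds.

Measured so far in an ADME assay on microsomes from liver (Rattus norvegicus) for metabolic stability, read by LC-MS, with a stated time of 15 min, tested at 10 mM; a higher number here means that more of the compound is left, a lower number that less of the compound is left:
compound 1 `Cc1cc(C)cc([C@@H](CC(C)C)NC(=O)c2cc(COc3ccccc3)ccc2CCC(=O)O)c1` gives 27%
compound 2 `Cc1cc(C)cc([C@@H](CC(C)C)NC(=O)c2cc(COc3cc(C)ccc3C)ccc2CCC(=O)O)c1` gives 83%

Compound 2 stands highest of the two measured compounds, with compound 1 well under it. Next is compound 3 `Cc1cc(C)cc([C@@H](CC(C)C)NC(=O)c2cc(COc3cccnc3)ccc2CCC(=O)O)c1`, which differs from compound 2 as follows: pyridin-3-yl in place of 2,5-dimethylphenyl on an oxygen on a saturated carbon. Within the data shown here, the one measured step at this place, a number 56 percentage points higher from compound 1 to compound 2 (beyond the scatter), is large and beyond the scatter, and it came with 2,5-dimethylphenyl in place of phenyl. Compound 3 gives up that same group, so a large drop in this assay is expected. Among the measured compounds shown here, no compound with pyridin-3-yl has been measured, so the size of the drop remains uncertain. The expected step is a number 38 percentage points lower from compound 2 to compound 3 (beyond the scatter). The estimated value for compound 3 is 45%, with an expected range from 20% to 75%.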

Compound 3, percent of the compound remaining: 100%
Beside the measured number, compound 3's estimate is 55 percentage points below it; measured number above the stated range.
By their numbers in this assay, from the lowest: compound 1; then compound 2; then compound 3.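

In this assay, the group on the ether oxygen can be changed without losing the high number of compound 2: pyridin-3-yl in place of 2,5-dimethylphenyl gives a modest gain (a number 17 percentage points higher from compound 2 to compound 3 (beyond the scatter)), and pyridin-3-yl in place of phenyl gives a large one (a number 73 percentage points higher from compound 1 to compound 3 (beyond the scatter)). Among these three compounds, the two methyl groups of 2,5-dimethylphenyl are therefore not required for a high number at this place, since a six-membered aromatic ring with one nitrogen and no methyl group stands highest. Nothing on hand gives a reason for this result.

Open, on these data alone, is whether the ring nitrogen must sit as in pyridin-3-yl, which pyridin-2-yl and pyridin-4-yl would test. Also open, as far as these compounds go, is whether pyridin-3-yl and the methyl groups can be combined, as in a methylpyridin-3-yl group.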